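Hexyloxy in place of dimethylamino on a purine-like core

A few compounds are considered here, and "the series" means these few. Any claim that something is new, unique, unknown or untested is made for them only; others in the source may bear on it.

Three compounds share one core, each carrying a different group on the same aromatic carbon. Compound 1 `CN(C)c1nc(N)nc2c1ncn2/C=C1/CC1(CO)CO` bears a dimethylamino group, compound 2 `CCCNc1nc(N)nc2c1ncn2/C=C1/CC1(CO)CO` a propylamino group, and compound 3 `CCCCCCSc1nc(N)nc2c1ncn2/C=C1/CC1(CO)CO` a hexylthio chain. The read-out of interest is an ADME assay on MOLT-3 cells (Homo sapiens) for cytotoxicity, with a stated time of 7 days; a lower number here means that less compound is tolerated, a higher number that more compound is tolerated. For compound 1 the outcome is "not determined" (no result reported). For compound 2 it is likewise "not determined" (no result reported). Compound 3 reaches only a limit of this assay, > 20000 nM. Within the data shown here, this limit is where the limit of > 20000 nM in this assay, at which 1 of the 3 values shown sits, sits, so compound 1 has no number to stand on, and the only measured neighbour stops at the edge of the assay rather than at a value.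

Compound 4 `CCCCCCOc1nc(N)nc2c1ncn2/C=C1/CC1(CO)CO` is the unmeasured one. It differs from compound 1 in that (hexyloxy in place of dimethylamino on an aromatic carbon). Among the measured compounds shown here, because no value exists for compound 1, no step to compound 4 can be sized; the expectation is only that compound 4 will also be tolerated up to the edge of this assay, like compound 3. Compound 4 is therefore expected to give 20000 nM, with an estimated range from 8000 nM to 60000 nM.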

Compound 4, half-maximal cytotoxic concentration: > 20000 nM
Compound 4 was reported as a limit; the forecaster's own chance of this, stated with the estimate: 75%; the middle value lies on the limit itself.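

Compound 3 and compound 4 both end at a limit in this assay rather than at a number, so no step between them can be read: the limit of > 20000 nM in this assay, at which 2 of the 4 values shown sit.
The compounds shown leave open at what concentration compound 3 or compound 4 would harm these cells, and whether hexyloxy and hexylsulfanyl differ at all.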